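The source may hold more compounds than are shown below. What is called first, only, known or untested is meant among the compounds shown, and "the series" means these compounds.

In a functional assay on the whole organism (Tail, strain ICR) with Mus musculus as the target, in the tail flick test, with a stated time of 60 min, at a dose of 25 umol/kg by the oral route (a higher number here means a stronger effect of the compound at the dose given, a lower number a weaker effect), compound 1 `C[C@H](NC(=O)CN(c1nc(Cl)nc2[nH]cnc12)C1CC1)C(=O)OCc1ccccc1` gives 64.3%, and compound 2 `N=C(N)NCCC[C@H](NC(=O)CN(c1nc(Cl)nc2[nH]cnc12)C1CC1)C(=O)O` gives 51%. On these two numbers compound 2 stands at the lower of the pair; its nearest neighbour is compound 1, whose result lies higher by a margin beyond the usual scatter. For the measured compounds named here, no other measured pair shares the same single point of difference, so no measured step can be carried over directly.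

Compound 3 `CC[C@H](C)[C@H](NC(=O)CN(c1nc(Cl)nc2[nH]cnc12)C1CC1)C(=O)O` has not yet been measured in this assay. It differs from compound 2 in one place: a group of 4 heavy atoms (4 carbon; no ring) in place of a group of 7 heavy atoms (4 carbon, 3 nitrogen; no ring), on a saturated chain carbon bound to an amide-type nitrogen and a carbonyl carbon. Going by the values given here, the only guide for the direction of this change is the gap between compound 2 and compound 1, which both share the common core and differ only away from it.

The account expects compound 3 to give about 57% in this assay, with a range from 40% to 72%, an estimate that rests on compound 1 at 64.3% and compound 2 at 51%. The expected step of a number 6 percentage points higher from compound 2 to compound 3 (within the scatter) is a modest rise, and it may well remain within the scatter.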

Compound 3, a percentage reported as activity, at one dose (the size of the read-out at that dose, not a potency): 36%
The estimate for compound 3 lay 21 percentage points above the measured number, and the stated range ends above it.
By their numbers in this assay, from the lowest: compound 3; then compound 2; then compound 1.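

In this assay, the group on the saturated chain carbon bound to an amide-type nitrogen and a carbonyl carbon matters for the read-out: placing sec-butyl there instead of the chain of 7 heavy atoms gives a number 15 percentage points lower from compound 2 to compound 3 (beyond the scatter), a change that goes beyond the usual scatter. For the compounds shown here, this is the first view of that position with everything else held constant, since compound 1 differs from compound 2 in more than one place and so could not isolate it. In this single pair, the all-carbon sec-butyl group, with no hydrogen-bond donors, goes with the weaker effect, but no measurement shown explains the drop.

The compounds shown leave open which part of the leaving chain carries the difference, for example whether a longer chain ending in a primary amine, or one ending in a carboxylic acid, would hold the read-out nearer that of compound 2. They also leave open whether a plain methyl group at this position, with the rest of compound 3 unchanged, would fall above or below compound 3.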